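Working notes: from compound 2 to compound 3

This account rests on a few compounds, and the source may have more. Where it says the series, first, only, none or still open, it means among the compounds named here.

Measured so far:
compound 1 `C[C@@H](O)CCn1nc2c(Br)c(Br)c(Br)c(Br)c2n1` gives 64%
compound 2 `OC(CCn1nc2c(Br)c(Br)c(Br)c(Br)c2n1)c1ccc(Br)cc1` gives 15%

In a functional assay on MCF7 cells (Homo sapiens) for antiproliferative activity, read by MTT assay, with a stated time of 48 h, tested at 50 uM (a lower number here means a stronger effect, a higher number a weaker effect of the compound at the concentration tested), compound 2 gives 15%, the lower of the two numbers; compound 1 gives 64%, a gap beyond the usual scatter. Compound 3 `CC(O)CCn1nc2c(Br)c(Br)c(Br)c(Br)c2n1` is not yet measured. It differs from compound 2 by methyl in place of 4-bromophenyl on a saturated chain carbon bound to an oxygen on a saturated carbon and a saturated chain carbon. Among the measured compounds shown here, no measured pair covers this change. Compound 1, which carries the same methyl, gives 64%. A step of a number 47 percentage points higher from compound 2 to compound 3 (beyond the scatter) toward a weaker effect is therefore expected. Compound 3 is estimated at 62%, within 45% to 80%.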

Compound 3, a percentage reported as activity, at one concentration (the size of the read-out at that concentration, not a potency): 76%
Estimate against measurement, compound 3: 14 percentage points below; low and high end bracket the measured number.
By their numbers in this assay, from the lowest: compound 2; then compound 1; then compound 3.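

In this assay, among the compounds shown here, methyl in place of 4-bromophenyl gives the first single-place reading at this carbon: a number 61 percentage points higher from compound 2 to compound 3 (beyond the scatter), a large loss of effect. At the same carbon, a change in the drawn configuration alone comes with a number 12 percentage points higher from compound 1 to compound 3 (beyond the scatter), a modest step set against the larger one. No atom or bond changes in that second step: the fact that one of compounds 1 and 3 is drawn with a defined configuration and the other without, at the place where they differ

The compounds shown leave open whether a plain phenyl or a longer alkyl chain on this carbon would keep the stronger effect of compound 2, and what the opposite defined configuration of the methyl compound would give.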